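A few compounds are considered here, and "the series" means these few. Any claim that something is new, unique, unknown or untested is made for them only; others in the source may bear on it.

Measured so far in a functional assay on HeLa cells (Homo sapiens) for cytotoxicity, with a stated time of 72 h; on this read-out lower numbers stand for higher toxicity in this test and higher numbers for lower toxicity in this test:
- compound 1 `CCCCCCCCCCCC/C=C\N(NC(=O)COC)C(=O)CCCCCCCCC`: 108000 nM
- compound 2 `CCCCCCCCCCCC/C=C\N(NC(=O)COC)C(=O)OC(C)(C)C`: 85300 nM

Among the measured compounds shown here, compound 2 cannot be told apart from compound 1 on these numbers, as the one measured step, a 1.3-fold lower number from compound 1 to compound 2 (0.10 log units; within the scatter), shows. Compound 3 `CCCCCCCC/C=C\N(NC(=O)COC)C(=O)OC(C)(C)C` differs from compound 2 on the long chain: hydrogen in place of butyl on a saturated chain carbon, eight bonds along the chain from a double-bonded chain carbon. For the measured compounds named here, that measured step concerns a carbonyl carbon, and no measured pair varies the chain, so it bears on this change only indirectly. No shift beyond the scatter is therefore expected in this assay. The expected step is a 1.3-fold higher number from compound 2 to compound 3 (0.11 log units; within the scatter). For compound 3 the estimated value is 110000 nM, with an expected range of 45000 nM to 260000 nM.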

Compound 3, half-maximal cytotoxic concentration: 105000 nM
Beside the measured number, compound 3's estimate is 1.0-fold (0.02 log units) above it; low and high end bracket the measured number.
By their numbers in this assay, from the lowest: compounds 2, 3 and 1 (each within the scatter of the next).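

The first measured variation of the long chain in this assay is hydrogen in place of butyl on a saturated chain carbon, eight bonds along the chain from a double-bonded chain carbon, with a 1.2-fold higher number from compound 2 to compound 3 (0.09 log units; within the scatter) in the result. At this position, then, the two chain lengths cannot be told apart in this test. Nothing available explains this result.

On these data alone, whether an amine, a carboxylic acid or a longer chain in place of butyl would give a step beyond the scatter stays open. As far as these compounds go, whether the same chain change would read alike with nonyl in place of tert-butoxy is also open.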